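A few compounds are considered here, and "the series" means these few. Any claim that something is new, unique, unknown or untested is made for them only; others in the source may bear on it.

Measured compounds:

Compound 1, `C=C(Br)C(=O)Nc1ccc(C(=O)/C=C/c2cccc(OC)c2)cc1`, gives 500 nM in a functional assay on HeLa cells (Homo sapiens) for antiproliferative activity, with a stated time of 48 h; a higher number here means a weaker inhibitor, a lower number a stronger inhibitor.
Compound 2, `C=C(Br)C(=O)Nc1ccc(C(=O)/C=C/c2cccc(OC)c2OC)cc1`, gives 380 nM.
Compound 3, `COc1cc(/C=C/C(=O)c2ccc(N)cc2)cc(OC)c1`, gives 7900 nM.

Compounds 1 and 2 differ in one place, (methoxy in place of hydrogen on an aromatic carbon), and this change gave a 1.3-fold lower number from compound 1 to compound 2 (0.12 log units; within the scatter). Compound 3 stands highest of the three numbers, and its core is not the same as that of compound 1; how the two cores differ is not broken down here.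

Compound 4, `COc1cc(/C=C/C(=O)c2ccc(N)cc2)cc(OC)c1OC`, is not yet measured. It differs from compound 3 by methoxy in place of hydrogen on an aromatic carbon. For the measured compounds named here, this is the same kind of change as the one from compound 1 to compound 2, though not the same: in compound 2 the new methoxy sits ortho to a large group and ortho to a methoxy group, whereas in compound 4 it sits ortho to two methoxy groups and para to a large group.

Beside the earlier step of a 1.3-fold lower number from compound 1 to compound 2 (0.12 log units; within the scatter), the step expected here is a 1.3-fold lower number from compound 3 to compound 4 (0.12 log units; within the scatter), resting on that one measured pair. Compound 4 is therefore expected to give about 6000 nM, with a range from 2500 nM to 15000 nM.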

Compound 4, half-maximal inhibitory concentration: 6900 nM
For compound 4 the middle estimate is 1.2-fold (0.06 log units) below the measured one; the measured number falls inside the stated range.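

In this assay, methoxy in place of hydrogen on an aromatic carbon gave a 1.1-fold lower number from compound 3 to compound 4 (0.06 log units; within the scatter), a step too small to tell apart from the differences seen between repeated measurements. Set beside the earlier step, the change looks alike on the two cores, and in neither case does it move the number by a clear amount: the same change on two cores in this assay, a 1.3-fold lower number (0.12 log units; within the scatter) from compound 1 to compound 2 and a 1.1-fold lower number (0.06 log units; within the scatter) from compound 3 to compound 4, 1.1-fold (0.06 log units) apart, within the scatter of two such steps

For the compounds shown here, this shows only that a small step on one core went with a small step on the other, even though the new methoxy sits in a different place in each pair; it rests on two pairs and does not establish a general rule for the series, nor does it show that a larger effect would carry across cores.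

The compounds shown leave open whether an ethoxy or a hydroxyl in the same place would give a step beyond the scatter. They also leave open whether the methoxy step would stay this small on a core carrying a carboxylic acid.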